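The compounds below may be only part of what the source reports. "The series", "measured", "known", "first", "only" and "open" are said of these compounds alone.

Measured so far in a functional assay on HCT-116 cells (Homo sapiens) for antiproliferative activity, read by sulforhodamine B assay, with a stated time of 72 h; a lower number here means a stronger inhibitor, a higher number a weaker inhibitor:
- compound 1 `CCCCS(=O)(=O)Nc1cc(-c2ccc3ncnc(NCCN(C)C)c3c2)cnc1OC`: 160 nM
- compound 2 `COc1ncc(-c2ccc3ncnc(NCCN(C)C)c3c2)cc1NS(C)(=O)=O`: 13500 nM
- compound 3 `CCCCS(=O)(=O)Nc1cc(-c2ccc3ncnc(NCc4ccncc4)c3c2)cnc1OC`: 5720 nM

Among the three, compound 3 at 5720 nM holds the second highest number. Compound 2 at 13500 nM lies above it, and compound 1 at 160 nM lies far lower.

Compound 4 `COc1ncc(-c2ccc3ncnc(NCc4ccncc4)c3c2)cc1NS(=O)(=O)c1ccc(F)cc1F` keeps the pyridin-4-yl of compound 3 and carries 2,4-difluorophenyl in place of butyl on a sulfonyl sulfur.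

Among the measured compounds shown here, two measured steps bear on this. The closer one acts at the same sulfonyl sulfur: an 84-fold higher number from compound 1 to compound 2 (1.93 log units; beyond the scatter), with hydrogen in place of propyl. It shows that the group on that sulfur can move the number in this assay strongly, and the butyl of compound 1 comes out ahead. For the measured compounds named here, the other, a 36-fold higher number from compound 1 to compound 3 (1.55 log units; beyond the scatter), lies elsewhere in the molecule and shows only that compound 3 starts from a high number. No aromatic group on the sulfonyl sulfur has been measured, so the data fix neither direction nor size. A moderate move to a lower number is expected, with a wide margin, and the estimate means a 3.8-fold lower number from compound 3 to compound 4 (0.58 log units; beyond the scatter). For compound 4 the estimated value is 1500 nM, with an expected range of 250 nM to 8000 nM.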

Compound 4, half-maximal inhibitory concentration: 17600 nM
For compound 4 the middle estimate is 12-fold (1.07 log units) below the measured one; measured number outside the range, above it.
By their numbers in this assay, from the lowest: compound 1; then compound 3; then compounds 2 and 4 (each within the scatter of the next).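

In this assay, among the compounds shown here, the first aromatic group on the sulfonyl sulfur does not improve on butyl: 2,4-difluorophenyl gives a 3.1-fold higher number from compound 3 to compound 4 (0.49 log units; beyond the scatter). Butyl now has the lower number in both pairs that differ at this sulfur, since an 84-fold higher number from compound 1 to compound 2 (1.93 log units; beyond the scatter) points the same way, and neither pair goes against this; however, the first pair carries (dimethylamino)methyl on the side chain and the second pyridin-4-yl, so the two step sizes are not set against each other here. Nothing at hand explains the loss seen with 2,4-difluorophenyl.

From the compounds shown here alone, whether 2,4-difluorophenyl would give a similar step with the (dimethylamino)methyl side chain of compound 1 remains open, so the present step cannot be carried over to that side chain. Going by these compounds, it is also open how a plain phenyl, a benzyl or a chain longer than butyl on the sulfonyl sulfur would compare, and whether the fluorines or the ring itself account for the higher number of compound 4.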